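Swapping Nitro for Bromo: Solubility Outlook

The source may report more compounds than this note shows. Statements on the series, on what has been measured and on what is new or still open speak of the compounds shown alone.

Measured so far:
Compound 1, `COC(=O)c1ccc(C(=O)/C(=C\c2ccc(F)c([N+](=O)[O-])c2)SCc2ccc(Br)cc2)cc1`: in a physicochemical assay for solubility (a lower number here means a less soluble compound, a higher number a more soluble compound), compound 1 gives < 1000 ug/mL, which is a limit of the assay.
Compound 2, `O=C(O)c1ccc(C(=O)/C(=C\c2ccc(O)c([N+](=O)[O-])c2)SCc2ccc(Br)cc2)cc1`: in this assay compound 2 gives < 1000 ug/mL, also a limit of the assay.

Compound 2 therefore stands at the limit of < 1000 ug/mL in this assay, at which 2 of the 2 values shown sit, so no exact number is known for it. Compound 3, `O=C(O)c1ccc(C(=O)/C(=C\c2ccc(O)c(Br)c2)SCc2ccc(Br)cc2)cc1`, differs from compound 2 by bromo in place of nitro on an aromatic carbon. Within the data shown here, no measured step is available to size this change in this assay, so a shift in either direction, or none beyond the scatter, remains open. Compound 3 is expected to give 150 ug/mL, within 15 ug/mL to 900 ug/mL. This expectation corresponds to a step that the limit leaves unreadable from compound 2 to compound 3.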

Compound 3, solubility: < 1000 ug/mL
Compound 3 gave a limit, no number (the forecaster's own chance of this, stated with the estimate: 75%); the middle value does not contradict the limit.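

Among these compounds, no step from compound 2 to compound 3 can be read in this assay, since both values are limits of the assay: the limit of < 1000 ug/mL in this assay, at which 3 of the 3 values shown sit.

As far as these compounds go, whether bromo in place of nitro shifts this read-out at all, and in which direction, stays open.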